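The compounds below may be only part of what the source reports. "The series", "measured", "known", "first", "only" and "open" are said of these compounds alone.

Compound 3 `Nc1ccccc1NC(=O)c1ccc(COCNc2nc(Nc3cccc(Cl)c3)c3ncn(C4CCCC4)c3n2)cc1` stands second highest of the three compounds measured in a functional assay on HCT-116 cells (Homo sapiens) for antiproliferative activity, read by CCK-8 assay, with a stated time of 72 h, tested at 2 uM; a lower number here means a weaker effect, a higher number a stronger effect of the compound at the concentration tested; compound 3 gives 29.2%. Compound 2 `Nc1ccccc1NC(=O)c1ccc(COCNc2nc(Nc3ccccc3)c3ncn(C4CCCC4)c3n2)cc1` gives 75.2%, and compound 1 `CC(C)n1cnc2c(Nc3cccc(Cl)c3)nc(NCOCc3ccc(C(=O)Nc4ccccc4N)cc3)nc21` gives 7.12%. Going by the values given here, two measured steps lead to compound 3: a number 22.1 percentage points higher from compound 1 to compound 3 (beyond the scatter), which concerns a different place and does not bear on the change here, and a number 46 percentage points lower from compound 2 to compound 3 (beyond the scatter), which concerns the same ring that is exchanged in the next step and is the only guide to it.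

Compound 4 `Nc1ccccc1NC(=O)c1ccc(COCNc2nc(Nc3ccc(-c4ccccc4)cc3)c3ncn(C4CCCC4)c3n2)cc1` differs from compound 3 in one place: 4-phenylphenyl in place of 3-chlorophenyl on a nitrogen on an aromatic ring. Among the compounds with values here, the chloro that lowered the number in the step from compound 2 is gone, which argues for a rise, but no measured step tells what a second ring at this place does, and the larger group may go either way. On balance an upward step is expected, of uncertain size: a number 12.8 percentage points higher from compound 3 to compound 4 (beyond the scatter). For compound 4 the estimate in this assay is 42%, within 8% to 80%.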

Compound 4, a percentage reported as inhibition, at one concentration (the size of the read-out at that concentration, not a potency): 9.41%
Estimate against measurement, compound 4: 32.6 percentage points above, and the stated range covers the measured number.
By their numbers in this assay, from the lowest: compounds 1 and 4 (each within the scatter of the next); then compound 3; then compound 2.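

In this assay, the plain phenyl on the nitrogen is no longer the only comparison for a chloro: adding a phenyl to that ring gives a number 65.8 percentage points lower from compound 2 to compound 4 (beyond the scatter), so both substituted rings shown here fall short of the unsubstituted one. Losing the chloro therefore does not by itself restore the number, since exchanging 3-chlorophenyl for 4-phenylphenyl gives a number 19.8 percentage points lower from compound 3 to compound 4 (beyond the scatter), and this position accepts the larger group less well than the chloro in this single pair. Nothing available accounts for this drop. Still open, as far as these compounds go, is whether the loss follows the size of the added group or the place it occupies on the ring, as compound 3 and compound 4 differ in both. Also open, from the compounds shown here alone, is how a methoxy, an amine or a carboxylic acid on this ring would read in this assay, and whether any substituent here can match the plain phenyl.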